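A few compounds are considered here, and "the series" means these few. Any claim that something is new, unique, unknown or untested is made for them only; others in the source may bear on it.

Compound 2 `COc1cc2c(Oc3ccc(NC(=O)c4cc(-c5ccccc5)ccn4)cc3F)ccnc2cc1OCCCN1CCCCC1` and compound 1 `COc1cc2c(Oc3ccc(NC(=O)c4cc(-c5ccc(F)cc5)ccn4)cc3F)ccnc2cc1OCCCN1CCCCC1` share one core and differ in a single place: fluoro in place of hydrogen on an aromatic carbon. In a functional assay on A549 cells (Homo sapiens) for cytotoxicity, read by MTT assay, with a stated time of 72 h (a higher number here means a weaker inhibitor, a lower number a stronger inhibitor), compound 2 gives 1800 nM, and compound 1 gives 10100 nM, so this change produced a 5.6-fold higher number from compound 2 to compound 1 (0.75 log units; beyond the scatter). Compound 3 `COc1cc2c(Oc3ccc(NC(=O)c4nccc(-c5ccc(F)cc5)n4)cc3F)ccnc2cc1OCCCN1CCCCC1` carries a different core; the difference between the two cores is not broken down here, and in this assay compound 3 gives "not determined" (no result reported). Compound 4 `COc1cc2c(Oc3ccc(NC(=O)c4nccc(-c5ccc(F)cc5F)n4)cc3F)ccnc2cc1OCCCN1CCCCC1` differs from compound 3 by the same kind of change: fluoro in place of hydrogen on an aromatic carbon. The surroundings are not the same: here the incoming fluoro sits ortho to a large group and meta to a fluoro group, whereas in compound 1 it sits para to a large group. Among the compounds with values here, with no number for compound 3 and a different core, the size of this step cannot be read from the earlier one, and the only anchor is compound 1 with 10100 nM. Compound 4 is expected to give about 8000 nM in this assay, estimated to lie between 1500 nM and 40000 nM.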

Compound 4, half-maximal inhibitory concentration: 470 nM
Compound 4: middle estimate off by 17-fold (1.23 log units), on the high side; the measured number lies below the stated range.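

No step can be read from compound 3 to compound 4 in this assay, as compound 3 has no number there. What the 4-fluorophenyl to 2,4-difluorophenyl change does on this core stays open, and no evidence shown explains the result.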